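This account rests on a few compounds, and the source may have more. Where it says the series, first, only, none or still open, it means among the compounds named here.

Measured compounds:
compound 1, `CC(C(=O)NCc1ccc(C(C)(C)C)nc1N1CCCC1)c1ccc(NS(C)(=O)=O)c(F)c1`: 1.2 nM
compound 2, `CCCCN(C)c1cc(C(C)(C)C)ccc1CNC(=O)C(C)c1ccc(NS(C)(=O)=O)c(F)c1`: 1 nM

Both were tested in an assay on cells for antagonist activity at transient receptor potential cation channel subfamily V member 1 (Homo sapiens), read by FLIPR and calcium flux, with a stated time of 6 min; on this read-out lower numbers stand for stronger inhibition and higher numbers for weaker inhibition. Compound 1 gives 1.2 nM, and compound 2 gives 1 nM. Compound 2 holds the lowest number of the two, but its nearest neighbour, compound 1, lies within the scatter of it, so no order between them can be claimed. Going by the values given here, no single-point step between measured compounds is available to guide the next change.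

Compound 3, `CCCCCc1cc(C(C)(C)C)ccc1CNC(=O)C(C)c1ccc(NS(C)(=O)=O)c(F)c1`, is yet to be measured. It differs from compound 2 in one place: pentyl in place of butyl(methyl)amino on an aromatic carbon. The change sits ortho to a large group and meta to a tert-butyl group, and removes a hydrogen-bond acceptor while keeping a chain of similar length. Among the compounds with values here, with no measured step of this kind to draw on, a small movement toward a higher number, close to the scatter, is expected, and the step of a 2.0-fold higher number from compound 2 to compound 3 (0.30 log units; within the scatter) expresses that. Compound 3 is therefore estimated at 2 nM, within the range 0.6 nM to 7 nM.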

Compound 3, inhibition constant: 2.8 nM
Estimate against measurement, compound 3: 1.4-fold (0.15 log units) below; measured number inside the range.
By their numbers in this assay, from the lowest: compounds 2 and 1 (each within the scatter of the next); then compound 3.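

In this assay, going by these compounds alone, pentyl in place of butyl(methyl)amino on an aromatic carbon gives a 2.8-fold higher number from compound 2 to compound 3 (0.45 log units; beyond the scatter) and so supplies the first single-place step. This shows that the position, ortho to a large group and meta to a tert-butyl group, responds to this change beyond the scatter, although the size of the step is modest. No measurement offered here accounts for the step.

The compounds shown do not separate the loss of the nitrogen from the change in chain, since the two go together in this one step. On these data alone, how a butoxy chain, a hexyl chain or a dimethylamino group would read at this position remains open.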